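The source may hold more compounds than are shown below. What is called first, only, known or untested is meant among the compounds shown, and "the series" means these compounds.

Compound 1 `S=C(Nc1ccccc1)OCCc1ccccn1` is a thiocarbamate whose aromatic ring carries no extra group. In an ADME assay on MT4 cells (Homo sapiens) for cytotoxicity, read by MTT assay (a higher number here means that more compound is tolerated, a lower number that less compound is tolerated), compound 1 gives > 100000 nM, which is a limit of the assay rather than a number. Compound 2 `CC(=O)c1ccc(NC(=S)OCCc2ccccn2)cc1` carries an acetyl on that ring; in this assay compound 2 gives >= 100000 nM, also a limit. Compound 3 `CN(C)c1ccc(NC(=S)OCCc2ccccn2)cc1` carries a dimethylamino at the same place and gives 60000 nM in this assay. So compound 1 stands only at a limit, and one of the two other values is a limit as well.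

Compound 4 `O=[N+]([O-])c1ccc(NC(=S)OCCc2ccccn2)cc1` differs from compound 1 in one place: nitro in place of hydrogen on an aromatic carbon. Two measured steps put a group at this same aromatic carbon. The first, a step that the two limits leave unreadable from compound 1 to compound 2, is unreadable, as both ends sit at a limit (the limit of > 100000 nM in this assay, at which 1 of the 3 values shown sits, and (the limit of >= 100000 nM in this assay, at which 1 of the 3 values shown sits)). Within the data shown here, the second, an at least 1.6-fold lower number from compound 1 to compound 3 (0.22 log units; that floor lies within the scatter), has a floor that lies within the scatter, so it shows no step that can be trusted. Neither step gives a reason to expect a change beyond the scatter for a nitro at this place.

Compound 4 is therefore expected to give about 100000 nM in this assay, within a range of 40000 nM to 200000 nM, most likely again reported as a limit. That estimate means a step of a number no higher from compound 1 to compound 4 (the limit leaves the size open).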

Compound 4, half-maximal cytotoxic concentration: > 100000 nM
Compound 4: a limit, no number; the forecaster's own chance of this, stated with the estimate: 65%; the middle value lies on the limit itself.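

Compound 4 adds a third group at this aromatic carbon that ends at a limit of this assay rather than at a number, so among the compounds shown only compound 3, with its dimethylamino, gives a number. The one step that can be partly read is an at least 1.6-fold higher number from compound 3 to compound 4 (0.22 log units; that floor lies within the scatter), so the compounds shown do not separate nitro from dimethylamino by more than the scatter. The steps to compound 4 from compound 1 and from compound 2 cannot be read, because both ends of each step sit at a limit: the limit of > 100000 nM in this assay, at which 2 of the 4 values shown sit.

The limits leave open how much compound the cells would tolerate for compound 1, compound 2 and compound 4, so no order among these three can be given. Among these compounds, it also stays open whether a different group at this same aromatic carbon, such as a carboxylic acid or a primary amine, would give a number, and whether that number would lie nearer to the one for compound 3 or to the limit.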